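Methyl for methoxy on the acid of compound 2

A few compounds are considered here, and "the series" means these few. Any claim that something is new, unique, unknown or untested is made for them only; others in the source may bear on it.

Compound 2 `COc1ccc(C(=O)c2sc(Nc3ccc(F)cc3)c(C(=O)O)c2C)cc1` is the weaker of the two numbered entries in a functional assay, with a stated time of 150 min, tested at 25 ug/mL; a lower number here means a weaker effect, a higher number a stronger effect of the compound at the concentration tested: compound 2 gives 0.836%, while compound 1 `COC(=O)c1c(Nc2ccc(F)cc2)sc(C(=O)c2ccc(OC)cc2)c1C` gives 20.2%. Going by the values given here, the only measured step, a number 19.4 percentage points lower from compound 1 to compound 2 (beyond the scatter), concerns a hydrogen in place of methyl on an oxygen next to a carbonyl group. A third compound, compound 3 `COc1ccc(C(=O)c2sc(Nc3ccc(Cl)cc3)c(C(=O)O)c2C)cc1`, was recorded in this assay as "not active" (no number reported). Compound 4 `Cc1ccc(C(=O)c2sc(Nc3ccc(F)cc3)c(C(=O)O)c2C)cc1` differs from compound 2 by methyl in place of methoxy on an aromatic carbon. Among the compounds with values here, no measured step touches this position, so the data give no direction for it; because compound 2 already sits at 0.836%, compound 4 is expected to stay near that low level, with a number 1.2 percentage points higher from compound 2 to compound 4 (within the scatter) within the scatter. The estimate for compound 4 is 2%, ranging from 0% to 14%.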

Compound 4, a percentage reported as activity, at one concentration (the size of the read-out at that concentration, not a potency): "not active" (no number reported)
Nothing numeric was reported for compound 4, so the estimate cannot be set against anything.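

Going by these compounds alone, compound 4 gives no number in this assay, so no step from compound 2 to compound 4 can be read. The compounds shown leave open how 4-methoxyphenyl and 4-methylphenyl compare among the acids. No evidence bears on this result.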